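The source may report more compounds than this note shows. Statements on the series, on what has been measured and on what is new or still open speak of the compounds shown alone.

Working notes on the series.

For the measured compounds named here, compound 1 `CCCN(CCC)c1c(C)nc(-c2c(C)cc(C)cc2OC)nc1OC` is the reference point: in an in vitro assay on IMR-32 cells for displacement of a labelled ligand from corticotropin-releasing factor receptor 1 (Homo sapiens) (on this read-out lower numbers stand for stronger inhibition and higher numbers for weaker inhibition), compound 1 gives 15 nM, the only number so far. Compound 2 `CCCN(CCC)c1c(C)nc(-c2c(C)cc(C)cc2OC)nc1OC(C)C` gives > 5000 nM in this assay, which is a limit of the assay and not a number, the compound sitting at the limit of > 5000 nM in this assay, at which 1 of the 2 values shown sits. Going by the values given here, the one measured step, an at least 330-fold higher number from compound 1 to compound 2 (2.52 log units; beyond the scatter), concerns isopropyl in place of methyl on an oxygen on an aromatic ring.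

Compound 3 `CCCc1nc(-c2c(C)cc(C)cc2OC)nc(OC)c1N(CCC)CCC` differs from compound 1 by ethyl in place of hydrogen on a saturated chain carbon bound to an aromatic carbon. The measured step sits at a different place, on an oxygen on an aromatic ring, and does not bear on a saturated chain carbon bound to an aromatic carbon. Among the compounds with values here, no measured step in this assay covers the change from compound 1 to compound 3. The expectation for compound 3 is therefore a step of a 1.3-fold lower number from compound 1 to compound 3 (0.10 log units; within the scatter), within the scatter. Compound 3 is estimated at 12 nM in this assay, between 4 nM and 50 nM.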

Compound 3, inhibition constant: 76 nM
The estimate for compound 3 lay 6.3-fold (0.80 log units) below the measured number; the whole stated range lies below it.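

The saturated chain carbon bound to an aromatic carbon responds to substitution: ethyl in place of hydrogen, which read one bond further out is methyl to propyl, brings a 5.1-fold higher number from compound 1 to compound 3 (0.70 log units; beyond the scatter) in this assay. For the compounds shown here, the step is modest, and compound 3 keeps a measured number, whereas the one earlier change, on an oxygen on an aromatic ring, left compound 2 at a limit of the assay. Nothing among the data shown accounts for the step at the chain carbon.

As far as these compounds go, whether the number at this place keeps rising with a longer chain such as butyl, or shifts differently with an amine or a carboxylic acid there, stays open. With a single change shown at this place, no trend along the chain can be read.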